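Notes on an ester of compound 1 in a cytotoxicity read-out

The source may report more compounds than this note shows. Statements on the series, on what has been measured and on what is new or still open speak of the compounds shown alone.

Measured so far in a functional assay on NTUB1 cells (Homo sapiens) for cytotoxicity, read by MTT assay, with a stated time of 48 h; on this read-out higher numbers stand for weaker inhibition and lower numbers for stronger inhibition
- compound 1 `C=C1CC[C@@H]2[C@](C)(CO)[C@H](O)CC[C@@]2(C)[C@@H]1CCc1ccoc1` gives 39800 nM
- compound 2 `C=C1CC[C@@H]2[C@](C)(COC(=O)C(Cl)Cl)[C@H](OC(=O)C(Cl)Cl)CC[C@@]2(C)[C@@H]1CCc1ccoc1` gives 11300 nM

Compound 1 has the higher number of the two, and compound 2 sits below it by more than the usual scatter. The next compound, compound 3 `C=C1CC[C@@H]2[C@](C)(COC(=O)c3ccc([N+](=O)[O-])cc3)[C@H](O)CC[C@@]2(C)[C@@H]1CCc1ccoc1`, differs from compound 1 by a single change: (4-nitrophenyl)carbonyl in place of hydrogen on an oxygen on a saturated carbon. In words, (4-nitrophenyl)carbonyl stands in place of hydrogen on an oxygen on a saturated carbon. Within the data shown here, no measured pair isolates a single change, so this step has no direct precedent. Among the measured compounds shown here, the only guide is compound 2 at 11300 nM, itself an ester of compound 1, and one compound is thin support. A modest move toward stronger inhibition in this assay is expected, estimated as a 2.3-fold lower number from compound 1 to compound 3 (0.37 log units; beyond the scatter). For compound 3 the estimated value is 17000 nM, with an expected range from 6000 nM to 45000 nM.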

Compound 3, half-maximal inhibitory concentration: 23800 nM
The estimate for compound 3 lay 1.4-fold (0.15 log units) below the measured number; measured number inside the range.
By their numbers in this assay, from the lowest: compound 2; then compounds 3 and 1 (each within the scatter of the next).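

In this assay, (4-nitrophenyl)carbonyl in place of hydrogen on an oxygen on a saturated carbon gives a 1.7-fold lower number from compound 1 to compound 3 (0.22 log units; within the scatter), so this single change does not separate the two compounds. Among these compounds, this is the first step that isolates one place, and it shows that this large aromatic ester group can stand on this oxygen without a shift beyond the scatter. No measurement available here bears on the reason for this outcome.

The compounds shown leave open whether a different group on this same oxygen, such as acetyl or a longer acyl chain such as hexanoyl, would give a step beyond the scatter. They also leave open how (4-nitrophenyl)carbonyl would read on the other hydroxyl oxygen of the core of compound 1.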